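Shortening the Saturated Chain of Compound 2

This account rests on a few compounds, and the source may have more. Where it says the series, first, only, none or still open, it means among the compounds named here.

In a toxicity assay on MRC5 cells (Homo sapiens) for inhibition, read by MTT assay, with a stated time of 72 h (a lower number here means a stronger inhibitor, a higher number a weaker inhibitor), compound 1 (`CCCCCC(=O)OCCc1ccc(O)cc1`) gives 166000 nM and compound 2 (`CCCCCCCCCC(=O)OCCc1ccc(O)cc1`) gives 172000 nM as its reading. Among the measured compounds shown here, these are the only two numbers available so far, and compound 2 stands level with compound 1, inside the usual scatter of repeated measurements. Compound 3 (`CCCCCCCC(=O)OCCc1ccc(O)cc1`) has not yet been measured. It departs from compound 2 as follows: hydrogen in place of ethyl on a saturated chain carbon, seven bonds along the chain from a carbonyl carbon. For the measured compounds named here, one measured step bears on this change, namely butyl in place of hydrogen on a saturated chain carbon, five bonds along the chain from a carbonyl carbon (a 1.0-fold higher number from compound 1 to compound 2 (0.02 log units; within the scatter)). That larger extension left the reading unmoved beyond the scatter, and compound 3 carries a chain shorter than that of compound 2 yet longer than that of compound 1. No step beyond the scatter is therefore expected (estimated: a 1.0-fold lower number from compound 2 to compound 3 (0.01 log units; within the scatter)). In this assay the value expected for compound 3 is 170000 nM with an estimated range (100000 nM to 280000 nM).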

Compound 3, half-maximal inhibitory concentration: 133000 nM
Beside the measured number, compound 3's estimate is 1.3-fold (0.11 log units) above it; low and high end bracket the measured number.
By their numbers in this assay, from the lowest: compounds 3, 1 and 2 (each within the scatter of the next).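

In this assay, taking ethyl off the saturated chain carbon, seven bonds along the chain from a carbonyl carbon, gives a 1.3-fold lower number from compound 2 to compound 3 (0.11 log units; within the scatter), and the smaller extension of the chain by ethyl gives a 1.2-fold lower number from compound 1 to compound 3 (0.10 log units; within the scatter); both steps lie within the scatter. The earlier pair offered only one extension, butyl in place of hydrogen, whereas the three chain lengths now shown do not separate from one another at either the shorter or the longer step, and no compound among them stands apart. Nothing measured here speaks to why these chain changes leave the reading where it is.

The compounds shown leave open whether a chain longer than that of compound 2, or one shorter than that of compound 1, would move the number in this assay beyond the scatter. They also leave open whether an amine or a carboxylic acid carried on the chain of compound 3 would give a reading that stands apart from these three.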